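Z to E double bond change in the series

A few compounds are considered here, and "the series" means these few. Any claim that something is new, unique, unknown or untested is made for them only; others in the source may bear on it.

Compound 1 `CN(C[C@H]1Cc2ncccc2CN1)[C@H]1CCCc2cccnc21` reads 95%
Compound 2 `NC(=O)NC/C=C\CN(C[C@H]1Cc2ncccc2CN1)[C@H]1CCCc2cccnc21` reads 100%

Both readings come from an ADME assay on microsomes from liver (Homo sapiens) for metabolic stability, using NADPH, with a stated time of 10 min (on this read-out lower numbers stand for a less stable compound and higher numbers for a more stable compound), and they do not separate the two compounds. Compound 2 at 100% stands level with compound 1 and sits at the end of what this read-out can show.

Compound 3 `NC(=O)NC/C=C/CN(C[C@H]1Cc2ncccc2CN1)[C@H]1CCCc2cccnc21` is the next case. Its relation to compound 2 is simple: the two compounds have the same atoms and bonds and differ only in configuration as drawn: 1 of 3 stereo elements differ; a double bond is drawn Z in compound 2 and E in compound 3 and nothing else differs. Within the data shown here, no measured pair compares a double bond drawn E with one drawn Z, so the data give no direct size for this change. Among the measured compounds shown here, one measured step bears on it, and only loosely, since it concerns the whole chain and not its geometry. Because the full chain came with a number 5 percentage points higher from compound 1 to compound 2 (within the scatter) a change of configuration alone is expected to give no step beyond the scatter, and no direction can be argued from the data. The estimated step is a number 4 percentage points lower from compound 2 to compound 3 (within the scatter) and it should be read as no real change. For compound 3 the expected value is 96% with an estimated range from 85% to 100% on the same read-out.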

Compound 3, percent of the compound remaining: 93%
Compound 3: the middle estimate sits 3 percentage points above what was measured; low and high end bracket the measured number.
By their numbers in this assay, from the lowest: compounds 3, 1 and 2 (each within the scatter of the next).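

Among these compounds, the first direct comparison of double bond geometry on this chain gives a number 7 percentage points lower from compound 2 to compound 3 (within the scatter) in this assay, so this read-out does not separate the form drawn Z from the form drawn E. The chain with its double bond drawn E also leaves the reading level with the compound that lacks the chain, with a number 2 percentage points lower from compound 1 to compound 3 (within the scatter), so neither geometry of the chain gives a step beyond the scatter at this position. The comparison of compounds 2 and 3 can be read as one of geometry alone, with no other structural change entering it: the fact that compounds 2 and 3 differ only in the configuration as drawn

On these data alone, all three readings lie close together at the stable end of the read-out at a single stated time, so it stays open whether the geometry would matter in a compound with more room to fall in this assay. Also open, as far as these compounds go, is whether the reading would stay level with a carboxylic acid, an amine or a longer chain in place of this chain.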